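This account rests on a few compounds, and the source may have more. Where it says the series, first, only, none or still open, it means among the compounds named here.

Working notes on the series.

Compound 3 `Cc1ccc2ncc(S(=O)(=O)c3cccc(Cl)c3)c(N3CCC(C)CC3)c2c1` is followed here in an assay on isolated protein for displacement of a labelled ligand from metabotropic glutamate receptor 5 (Homo sapiens), with a stated time of 60 min, tested at 1 uM (a higher number here means more inhibition at the concentration tested (going by the name of the read-out), a lower number less inhibition), where compound 3 gives 91%. In this assay compound 1 `COc1ccc2ncc(S(=O)(=O)c3ccc(Cl)cc3)c(N3CCC(C)CC3)c2c1` gives 91%, and compound 2 `COc1cccc(S(=O)(=O)c2cnc3ccc(OC)cc3c2N2CCC(C)CC2)c1` gives 0%. Among the measured compounds shown here, the one single-point step among the measured compounds is a number 91 percentage points lower from compound 1 to compound 2 (beyond the scatter); it changes the aryl on the sulfonyl sulfur, not the substituent on the shared core. Compound 3 stands level with compound 1 at the digits printed, the two together at the top of the three numbers, and far above compound 2. For the measured compounds named here, compound 1 and compound 3 differ in two places at once, so no step is stated for that pair; their two values simply show the same inhibition with methoxy or methyl on the core and with either chlorophenyl on the sulfur.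

Compound 4 `COc1ccc2ncc(S(=O)(=O)c3cccc(Cl)c3)c(N3CCC(C)CC3)c2c1` differs from compound 3 by methoxy in place of methyl on an aromatic carbon. Going by the values given here, no measured step touches this position, so the expectation rests only on compound 1 and compound 3 carrying the two groups at matching values. In this assay the step of a number 1 percentage points lower from compound 3 to compound 4 (within the scatter) is expected to stay within the scatter. Compound 4 is estimated at 90%, with a range from 78% to 98%.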

Compound 4, a percentage reported as inhibition, at one concentration (the size of the read-out at that concentration, not a potency): -3%
Estimate against measurement, compound 4: 93 percentage points above, and the stated range ends above it.
By their numbers in this assay, from the lowest: compounds 4 and 2 (each within the scatter of the next); then compounds 1 and 3 (each within the scatter of the next).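

In this assay, the step of a number 94 percentage points lower from compound 3 to compound 4 (beyond the scatter) shows that methoxy in place of methyl on this aromatic carbon of the shared core is far from neutral when 3-chlorophenyl sits on the sulfonyl sulfur. The step of a number 94 percentage points lower from compound 1 to compound 4 (beyond the scatter) shows that, with methoxy on the core, 3-chlorophenyl in place of 4-chlorophenyl is enough to lose the read-out, so methoxy at this place does not remove inhibition on its own and the outcome of each change depends on the other. The step of a number 3 percentage points lower from compound 2 to compound 4 (within the scatter) stays within the scatter, so with methoxy on the core, the 3-chlorophenyl and 3-methoxyphenyl groups on the sulfur read alike in this assay. Nothing at hand bears on why these steps are so large.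

The compounds shown leave open whether methyl on the core would also hold the read-out with 3-methoxyphenyl or 4-chlorophenyl on the sulfur. They also leave open how an ethyl group, a fluoro group or an amine at this aromatic carbon would behave with each chlorophenyl.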